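Removing oxan-4-yl from compound 3

The compounds below may be only part of what the source reports. "The series", "measured", "known", "first", "only" and "open" are said of these compounds alone.

Measured so far in a physicochemical assay for lipophilicity, using the shake flask method, measured as octanol-water partition, at pH 7.4; a lower number here means a more polar compound, a higher number a more lipophilic compound:
compound 1 `CN(C)C(=O)CN1CCC(c2cc3c(-c4ccc(=O)n(CCC5CCOCC5)c4)ccnc3[nH]2)CC1` gives 1.5
compound 2 `CCn1cc(-c2ccnc3[nH]c(C4CCN(CC(=O)N(C)C)CC4)cc23)ccc1=O` gives 1.2
compound 3 `CN(C)C(=O)CN1CCC(c2cc3c(-c4ccc(=O)n(CC5CCOCC5)c4)ccnc3[nH]2)CC1` gives 1.4

The data show a number 0.20 log units higher from compound 2 to compound 3 (within the scatter) and also a number 0.10 log units lower from compound 1 to compound 3 (within the scatter) and so compound 3 cannot be told apart from either of the other two. Compound 4 `CN(C)C(=O)CN1CCC(c2cc3c(-c4ccc(=O)n(C)c4)ccnc3[nH]2)CC1` has not yet been measured. It differs from compound 3 by hydrogen in place of oxan-4-yl on a saturated chain carbon bound to an aromatic nitrogen. The nearest measured parallel is the same exchange on a saturated chain carbon, two bonds along the chain from an aromatic nitrogen, which gave a number 0.30 log units lower from compound 1 to compound 2 (within the scatter) as a small step. The reverse kind of exchange, oxan-4-yl in place of methyl, gave only a number 0.20 log units higher from compound 2 to compound 3 (within the scatter) as well. A small move to a lower number is therefore expected, with nothing clearly beyond the scatter. The expected step is a number 0.30 log units lower from compound 3 to compound 4 (within the scatter) and no more than that. In this assay the estimate for compound 4 is 1.1 with an expected range from 0.7 to 1.5 at its two ends.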

Compound 4, distribution coefficient: 1.1
The estimate for compound 4 equals the measured number at the digits printed, and the stated range covers the measured number.
By their numbers in this assay, from the lowest: compounds 4, 2, 3 and 1 (each within the scatter of the next, the first and the last beyond it).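

In this assay this place on a saturated chain carbon bound to an aromatic nitrogen now gives its first separation beyond the scatter, with a number 0.40 log units lower from compound 1 to compound 4 (beyond the scatter) on the exchange of (oxan-4-yl)methyl for hydrogen. The smaller exchanges at the same place do not separate their compounds, with a number 0.30 log units lower from compound 3 to compound 4 (within the scatter) on the loss of oxan-4-yl and a number 0.10 log units lower from compound 2 to compound 4 (within the scatter) on the exchange of methyl for hydrogen, so among these compounds only the largest exchange can be told from the scatter. The information at hand offers no explanation for this step.

The compounds shown leave open how an amine or a carboxylic acid at the end of this chain would read in this assay. On these data alone, it also remains open whether a longer plain alkyl chain without the oxan-4-yl ring would give a similar number.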